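Replacing a difluorophenyl with a pyridine on the piperazine arm

The compounds below may be only part of what the source reports. "The series", "measured", "known", "first", "only" and "open" are said of these compounds alone.

Measured so far:
Compound 1, `Cn1c(=O)c2[nH]c(-c3ccc(S(=O)(=O)N4CCN(c5ccccc5)CC4)cc3)cc2n(C)c1=O`: 6 nM
Compound 2, `Cn1c(=O)c2[nH]c(-c3ccc(S(=O)(=O)N4CCN(Cc5ccc(F)cc5F)CC4)cc3)cc2n(C)c1=O`: 7 nM
Compound 3, `Cn1c(=O)c2[nH]c(-c3ccc(S(=O)(=O)NC4CCN(Cc5ccccc5)CC4)cc3)cc2n(C)c1=O`: 43 nM

In an assay on HEK293 cells for displacement of a labelled ligand from adenosine receptor A2b (Homo sapiens) (a higher number here means a weaker inhibitor, a lower number a stronger inhibitor), compound 2 gives 7 nM. Among the three numbers it stands second highest; it sits close to compound 1, whose 6 nM is within the scatter of it, while compound 3 with 43 nM shows a clearly higher number.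

The next compound, compound 4, has the structure `Cn1c(=O)c2[nH]c(-c3ccc(S(=O)(=O)N4CCN(Cc5ccncc5)CC4)cc3)cc2n(C)c1=O`. It differs from compound 2 in one place: pyridin-4-yl in place of 2,4-difluorophenyl on a saturated chain carbon bound to an amine nitrogen in a ring.

Among the compounds with values here, only one measured step speaks to changes on this ring of the molecule, the step of a 1.2-fold higher number from compound 1 to compound 2 (0.07 log units; within the scatter), which was within the scatter. That step exchanged an aromatic ring hanging from the ring amine for another, and the number hardly moved. The present change again swaps one aromatic ring for another at the same arm, so in this assay the expected step of a 1.4-fold higher number from compound 2 to compound 4 (0.15 log units; within the scatter) is small, with no direction beyond the scatter to be claimed.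

Compound 4 is therefore estimated at 10 nM, with a range from 3 nM to 40 nM.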

Compound 4, half-maximal inhibitory concentration: 27 nM
Beside the measured number, compound 4's estimate is 2.7-fold (0.43 log units) below it; low and high end bracket the measured number.
By their numbers in this assay, from the lowest: compounds 1 and 2 (each within the scatter of the next); then compounds 4 and 3 (each within the scatter of the next).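

The aromatic ring on this arm cannot be exchanged freely in this assay, since pyridin-4-yl in place of 2,4-difluorophenyl gives a 3.9-fold higher number from compound 2 to compound 4 (0.59 log units; beyond the scatter) and so moves the number beyond the scatter, unlike the earlier change a 1.2-fold higher number from compound 1 to compound 2 (0.07 log units; within the scatter) on the same ring amine. Set against the directly attached phenyl, (pyridin-4-yl)methyl gives a 4.5-fold higher number from compound 1 to compound 4 (0.65 log units; beyond the scatter) as a modest step, so compound 4 sits clearly above both of these close neighbours. No measurement available here accounts for this shift.

The compounds shown leave open whether the higher number goes with the ring nitrogen or with the loss of the two fluorines, which a plain benzyl on this arm could help separate. Pyridin-2-yl or pyridin-3-yl in place of pyridin-4-yl could show whether the place of that nitrogen matters.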